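Sulfonyl Groups on the Ring Nitrogen and Cell Growth

The source may report more compounds than this note shows. Statements on the series, on what has been measured and on what is new or still open speak of the compounds shown alone.

compound 1, `COc1ccc(-c2cc(=O)c3c(OC)cc(OC)cc3n2C)cc1`: "not determined" (no result reported)
compound 2, `COc1ccc(-c2cc(=O)c3c(OC)cc(OC)cc3n2S(=O)(=O)c2ccc(C=O)cc2)cc1`: > 34400 nM
compound 3, `COc1ccc(-c2cc(=O)c3c(OC)cc(OC)cc3n2S(=O)(=O)c2ccc(C)c([N+](=O)[O-])c2)cc1`: > 51700 nM

The three measured compounds share the core of compound 1 and differ only in the group on the aromatic nitrogen. In a functional assay on HepG2 cells (Homo sapiens) for antiproliferative activity, with a stated time of 72 h (on this read-out higher numbers stand for an effect only at larger amounts of compound and lower numbers for an effect already at smaller amounts), compound 1 has no result at all; its entry reads "not determined" (no result reported). Compound 2 gives only a limit in this assay, > 34400 nM. Compound 3 likewise gives only a limit in this assay, > 51700 nM. Going by the values given here, the single measured step, a step that the two limits leave unreadable from compound 2 to compound 3, cannot be sized because both ends sit at the limits the limit of > 34400 nM in this assay, at which 1 of the 3 values shown sits, and (the limit of > 51700 nM in this assay, at which 1 of the 3 values shown sits).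

Compound 4, `COc1ccc(-c2cc(=O)c3c(OC)cc(OC)cc3n2S(=O)(=O)c2cccc(Br)c2)cc1`, is not yet measured. It differs from compound 1 by (3-bromophenyl)sulfonyl in place of methyl on an aromatic nitrogen. Among the compounds with values here, no measured step starts from compound 1, so nothing gives the size of this change directly. What the data do show is that the two compounds carrying a substituted phenylsulfonyl group on this nitrogen, compound 2 and compound 3, both stay beyond the measurable range in this assay. A third such group is expected to behave the same way. Compound 4 is therefore estimated at 50000 nM in this assay, within a range of 10000 nM to 200000 nM, most likely reported again as a limit.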

Compound 4, half-maximal effective concentration: > 58600 nM
Compound 4: a limit, no number; the forecaster's own chance of this, stated with the estimate: 75%; middle value at least 1.1-fold (0.06 log units) from the limit.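

In this assay compound 4 gives only a limit, > 58600 nM. With compound 2 and compound 3 also at limits, the steps from either of them to compound 4 cannot be read. The compounds shown leave open whether any group on the aromatic nitrogen gives a measurable effect in this assay, and how methyl in compound 1 compares with the sulfonyl groups.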